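The compounds below may be only part of what the source reports. "The series", "measured", "known", "first", "only" and "open" are said of these compounds alone.

Measured in an ADME assay on HEK293 cells (Homo sapiens) for inhibition, read by MTT assay, with stated times of 18 h and 4 h (a higher number here means a weaker inhibitor, a lower number a stronger inhibitor), every value a limit:
compound 1 `CCCOP(=O)(O)OCCSC(=S)N1CCCCC1`: > 100000 nM
compound 2 `CCCCCCCCCCCCCCCCOP(=O)(O)OCCSC(=S)N1CCN(C)CC1`: > 100000 nM
compound 3 `CCCOP(=O)(O)OCCSC(=S)N1CCCC1`: > 100000 nM

Compound 1 gives > 100000 nM, which is a limit and not a number. For the measured compounds named here, the series so far offers only (the limit of > 100000 nM in this assay, at which 3 of the 3 values shown sit), so compound 1 has no readable rank among the measured compounds.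

Compound 4 `CCCCCCOP(=O)(O)OCCSC(=S)N1CCCCC1` differs from compound 1 by one change, (propyl in place of hydrogen on a saturated chain carbon, three bonds along the chain from an oxygen on an unsaturated carbon), which lengthens propyl to hexyl.

Going by the values given here, the only measured step with a single change is a step that the two limits leave unreadable from compound 1 to compound 3. It alters pyrrolidin-1-yl in place of piperidin-1-yl rather than the chain, and it gives no size to carry over. Compound 2, which carries a hexadecyl chain, gives > 100000 nM, again a limit. This value offers no sign of a chain effect, though compound 2 also differs from compound 1 elsewhere.

No step beyond the scatter is expected in this assay, in either direction, and compound 4 will most likely be reported as a limit too. The expected step is a number no higher from compound 1 to compound 4 (the limit leaves the size open), an estimate that rests on limits alone. For compound 4 the estimated value is 100000 nM, with an expected range of 40000 nM to 200000 nM.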

Compound 4, half-maximal inhibitory concentration: > 100000 nM
Compound 4: no number, only a limit (the forecaster's own chance of this, stated with the estimate: 75%); the middle value lies on the limit itself.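

In this assay compound 4 gives > 100000 nM, which is a limit. No step can be read between compound 1 and compound 4, and every compound shown sits at the same limit: the limit of > 100000 nM in this assay, at which 4 of the 4 values shown sit.

The compounds shown leave open whether any chain length or any change in the shared core gives a numerical value in this assay.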